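The source may report more compounds than this note shows. Statements on the series, on what has been measured and on what is new or still open speak of the compounds shown alone.

Measured so far:
compound 1, `COc1nc2ccc(Br)cc2cc1C(c1ccccc1)n1cc(CCCCCO)nn1`, 19.6% in an ADME assay on PANC-1 cells (Homo sapiens) for cytotoxicity, read by sulforhodamine B assay, with a stated time of 48 h, tested at 10 uM; a higher number here means more inhibition at the concentration tested (going by the name of the read-out), a lower number less inhibition
compound 2, `CCCCCCCCc1cn(C(c2ccccc2)c2cc3cc(Br)ccc3nc2OC)nn1`, 12.1% in this assay

Compound 2 has the lower of the two numbers in this assay, yet the gap between the two is a number 7.5 percentage points lower from compound 1 to compound 2 (within the scatter). Compound 3, `COc1nc2ccc(Br)cc2cc1C(c1ccccc1)n1cc(CO)nn1`, has not been tested in this assay. Relative to compound 2 the change is hydroxy in place of heptyl on a saturated chain carbon bound to an aromatic carbon. Going by the values given here, only one measured step bears on it: between compound 1 and compound 2, a chain end was swapped with no step beyond the scatter. For compound 3 in this assay a step of a number 4.9 percentage points higher from compound 2 to compound 3 (within the scatter) is therefore expected, no more than scatter. The estimate for compound 3 is 17%, expected within 4% to 32%.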

Compound 3, a percentage reported as inhibition, at one concentration (the size of the read-out at that concentration, not a potency): 15%
Estimate against measurement, compound 3: 2 percentage points above; the range from low to high includes it.
By their numbers in this assay, from the lowest: compounds 2, 3 and 1 (each within the scatter of the next).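

In this assay, hydroxy in place of heptyl on a saturated chain carbon bound to an aromatic carbon gives a number 2.9 percentage points higher from compound 2 to compound 3 (within the scatter), and hydroxy in place of 4-hydroxybutyl gives a number 4.6 percentage points lower from compound 1 to compound 3 (within the scatter). Among these three compounds, then, the short hydroxymethyl end stands level with both longer chains, whether or not the chain carries a hydroxy. No further measurement bears on this result.

Still open, on these data alone, is whether a group of another kind at this place, such as an amine or a carboxylic acid, would move the number beyond the scatter.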